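Replacing ureido with 4-methylpiperazin-1-yl

The compounds below may be only part of what the source reports. "The series", "measured", "known", "first", "only" and "open" are said of these compounds alone.

Measured in a functional assay on SK-MEL-28 cells (Homo sapiens) for cytotoxicity, read by MTT assay, with a stated time of 3 days; on this read-out higher numbers stand for weaker inhibition and lower numbers for stronger inhibition:
- compound 1 `N#Cc1c(Nc2ccccn2)nc(SCc2nc3ccccc3[nH]2)nc1-c1ccccc1`: 8.9 nM
- compound 2 `N#Cc1c(Nc2nccs2)nc(SCc2nc3ccccc3[nH]2)nc1-c1ccccc1`: 8.9 nM
- compound 3 `N#Cc1c(NC(N)=O)nc(SCc2nc3ccccc3[nH]2)nc1-c1ccccc1`: 4.8 nM

Compound 3 stands within the scatter of both other compounds, as the steps show: a 1.9-fold lower number from compound 1 to compound 3 (0.27 log units; within the scatter) and a 1.9-fold lower number from compound 2 to compound 3 (0.27 log units; within the scatter). The remaining step is no change at the digits printed from compound 1 to compound 2 (within the scatter). All three exchanges on this nitrogen therefore leave the numbers within the scatter.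

The next change leads to compound 4 `CN1CCN(c2nc(SCc3nc4ccccc4[nH]3)nc(-c3ccccc3)c2C#N)CC1`, with 4-methylpiperazin-1-yl in place of ureido on an aromatic carbon. Among the compounds with values here, no measured compound carries this group, so the three steps bear on the change only indirectly. They cover substituents on a nitrogen, and none of them replaces that nitrogen's link to the aromatic carbon with a ring.

In this assay a small move towards a higher number is expected, with wide uncertainty. The expected step is a 2.1-fold higher number from compound 3 to compound 4 (0.32 log units; beyond the scatter). Compound 4 is estimated at 10 nM, with an expected range from 3 nM to 35 nM.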

Compound 4, half-maximal inhibitory concentration: 20 nM
For compound 4 the middle estimate is 2.0-fold (0.30 log units) below the measured one; the measured number falls inside the stated range.
By their numbers in this assay, from the lowest: compounds 3, 1 and 2 (each within the scatter of the next); then compound 4.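

Steps of a 4.2-fold higher number from compound 3 to compound 4 (0.62 log units; beyond the scatter) and a 2.2-fold higher number from compound 2 to compound 4 (0.35 log units; beyond the scatter) and a 2.2-fold higher number from compound 1 to compound 4 (0.35 log units; beyond the scatter) make 4-methylpiperazin-1-yl the only exchange at this position in this assay that goes beyond the scatter, and all three steps are modest. The position therefore tolerates the three nitrogen-linked groups alike, while this ring attached directly to the aromatic carbon gives a higher number than each of them. Against ureido, the exchange takes 2 hydrogen-bond donors down to 0 and adds a six-membered non-aromatic ring, and no measurement here explains the rise.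

The compounds shown do not separate the effect of the ring from that of the lost nitrogen-linked hydrogen, or from that of the methyl group. Morpholin-4-yl, unsubstituted piperazin-1-yl or dimethylamino on this aromatic carbon would bear on that question.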